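Swapping the amide substituent on a shared phosphatase-inhibitor core

The source may hold more compounds than are shown below. What is called first, only, known or untested is meant among the compounds shown, and "the series" means these compounds.

Measured compounds:
Compound 1 `O=C(COc1ccc2cc(C(O)(C(F)(F)F)C(F)(F)F)c(O)cc2c1)Nc1nc2ccccc2s1` gives 9900 nM in an assay on isolated protein for inhibition of tyrosine-protein phosphatase non-receptor type 13 (Homo sapiens), read by spectrophotometry; a lower number here means a stronger inhibitor, a higher number a weaker inhibitor.
Compound 2 `CC(C)c1ccc(NC(=O)COc2ccc3cc(C(O)(C(F)(F)F)C(F)(F)F)c(O)cc3c2)cc1` gives 6500 nM in this assay.
Compound 3 `Cc1ccc(S(=O)(=O)NNC(=O)COc2ccc3cc(C(O)(C(F)(F)F)C(F)(F)F)c(O)cc3c2)cc1` gives 14900 nM in this assay.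

All three compounds share the same core and differ only in the group attached to the amide-type nitrogen. Compound 1 sits second highest of the three numbers, with compound 3 nearest and compound 2 furthest, and both of those gaps lie within the scatter: a 1.5-fold lower number from compound 1 to compound 2 (0.18 log units; within the scatter) and a 1.5-fold higher number from compound 1 to compound 3 (0.18 log units; within the scatter). For the measured compounds named here, the only step that goes beyond the scatter is a 2.3-fold higher number from compound 2 to compound 3 (0.36 log units; beyond the scatter), and it is modest.

The unmeasured compound 4 `O=C(COc1ccc2cc(C(O)(C(F)(F)F)C(F)(F)F)c(O)cc2c1)NC1CC1` makes a different kind of change: cyclopropyl in place of 1,3-benzothiazol-2-yl on an amide-type nitrogen. The measured steps all replace one sizeable group on the amide-type nitrogen with another sizeable group, and they move the number only a little. None of them removes a ring system of this size in favour of cyclopropyl, so they bear on the step only loosely. The expectation is that compound 4 keeps roughly the activity of compound 1 or weakens somewhat, giving an estimated step of a 1.5-fold higher number from compound 1 to compound 4 (0.18 log units; within the scatter). Compound 4 is therefore estimated at 15000 nM, expected to fall between 5000 nM and 45000 nM.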

Compound 4, half-maximal inhibitory concentration: > 20000 nM
Compound 4: a limit, no number; the forecaster's own chance of this, stated with the estimate: 20%; middle value at least 1.3-fold (0.12 log units) from the limit.
By their numbers in this assay, from the lowest: compounds 2, 1 and 3 (each within the scatter of the next, the first and the last beyond it). At a limit, above all of these: compound 4.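

Compound 4 gives > 20000 nM in this assay, and this is a limit of the assay and not a number. Read as floors, the steps are an at least 3.0-fold higher number from compound 2 to compound 4 (0.48 log units; beyond the scatter), an at least 2.0-fold higher number from compound 1 to compound 4 (0.30 log units; that floor lies within the scatter) and an at least 1.3-fold higher number from compound 3 to compound 4 (0.12 log units; that floor lies within the scatter), so only the first floor shows compound 4 to be a weaker inhibitor, while the other two floors alone do not separate it from compound 1 or compound 3. The amide-type nitrogen therefore does not accept every group equally: the measured swaps among the three larger groups moved the number only a little, whereas cyclopropyl, with 3 heavy atoms against 9 in 1,3-benzothiazol-2-yl, gives a result clearly apart from compound 2 at the least.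

On these data alone, how far the true value of compound 4 lies past its limit remains open, and so does how much weaker it is than compound 1 or compound 3. It is also unresolved whether the count of heavy atoms or the loss of an aromatic ring matters more, a question that a plain phenyl, a longer alkyl chain or a chain ending in an amine on the same nitrogen could help to separate.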